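This account rests on a few compounds, and the source may have more. Where it says the series, first, only, none or still open, it means among the compounds named here.

Measured compounds:
compound 1 `Cc1ccc(-c2cccc(S(=O)(=O)N3CCC(N4CCC(C)CC4)CC3)c2)cc1` — a functional assay on DLD-1 cells (Homo sapiens) for antiproliferative activity, read by CellTiter-Glo, with a stated time of 72 h; a higher number here means a weaker inhibitor, a lower number a stronger inhibitor: 11 nM
compound 2 `CC1CCN(C2CCN(S(=O)(=O)c3cccc(-c4ccc(Cl)cc4)c3)CC2)CC1` — this assay: 15 nM
compound 3 `Cc1cc(C)cc(-c2cccc(S(=O)(=O)N3CCC(N4CCC(C)CC4)CC3)c2)c1` — this assay: 41 nM

Compound 3 gives the highest number of the three. Both steps leading to it lie beyond the scatter: a 3.7-fold higher number from compound 1 to compound 3 (0.57 log units; beyond the scatter) and a 2.7-fold higher number from compound 2 to compound 3 (0.44 log units; beyond the scatter). The step between the other two, a 1.4-fold higher number from compound 1 to compound 2 (0.13 log units; within the scatter), is within the scatter, so compound 1 and compound 2 cannot be ordered against each other.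

Compound 4 `CC1CCN(C2CCN(S(=O)(=O)c3cccc(-c4ccc5ccccc5c4)c3)CC2)CC1` is not yet measured. The change from compound 3 is naphthalen-2-yl in place of 3,5-dimethylphenyl on an aromatic carbon. The two steps that bear on this change are the same ones above: each shows that the 3,5-dimethylphenyl carries a modestly higher number than a phenyl bearing a single substituent. Among the measured compounds shown here, no measured compound carries a naphthalen-2-yl or any fused ring, so there is no direct precedent for the entering group. The expectation is that the number moves back down toward those of compound 1 and compound 2, by a modest amount, with wide uncertainty. Compound 4 is expected to give 20 nM, within 6 nM to 70 nM. The expected step is a 2.1-fold lower number from compound 3 to compound 4 (0.31 log units; beyond the scatter).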

Compound 4, half-maximal inhibitory concentration: 2 nM
The estimate for compound 4 lay 10-fold (1.00 log units) above the measured number; the whole stated range lies above it.
By their numbers in this assay, from the lowest: compound 4; then compounds 1 and 2 (each within the scatter of the next); then compound 3.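

At this aromatic carbon, meta to a large group, a fused second ring gives the strongest inhibitor of the series in this assay, with (a 21-fold lower number from compound 3 to compound 4 (1.31 log units; beyond the scatter)) against the 3,5-dimethylphenyl, (a 7.5-fold lower number from compound 2 to compound 4 (0.88 log units; beyond the scatter)) against the 4-chlorophenyl and (a 5.5-fold lower number from compound 1 to compound 4 (0.74 log units; beyond the scatter)) against the 4-methylphenyl. Among the compounds shown here, the earlier compounds carried only a single six-membered aromatic ring here, so they did not show that this position accepts naphthalen-2-yl, or that such a change can move the number further than any step among those phenyl groups. Nothing available accounts for this gain.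

Still open, as far as these compounds go, is whether the gain depends on the attachment through the 2-position of the fused ring, as a naphthalen-1-yl would test. Also open, from the compounds shown here alone, is whether the second ring must be all carbon, as a quinoline with its ring nitrogen would test.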